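The source may hold more compounds than are shown below. What is called first, only, known or untested is meant among the compounds shown, and "the series" means these compounds.

In an assay on isolated protein for inhibition of aldehyde dehydrogenase 1A1 (Homo sapiens), read by spectrophotometry, tested at 10 uM (a higher number here means more inhibition at the concentration tested (going by the name of the read-out), a lower number less inhibition), compound 1 `Cc1cccc(Cn2c(CN3CCN(C(=O)C4CCCC4)CC3)nc3ccccc32)c1` gives 67.5%, the highest of the three numbers. Among the compounds with values here, compound 2 `COc1cccc(Cn2c(CN3CCN(C(=O)C4CC4)CC3)nc3ccccc32)c1` gives 44.4% in this assay, and compound 3 `CCCCn1c(CN2CCN(C(=O)C3CC3)CC2)nc2ccccc21` gives 18.2%, the step of a number 26.2 percentage points lower from compound 2 to compound 3 (beyond the scatter) being the only single-point change measured. Compound 4 `Cc1cccc(Cn2c(CN3CCN(C(=O)c4ccncc4)CC3)nc3ccccc32)c1` differs from compound 1 by pyridin-4-yl in place of cyclopentyl on a carbonyl carbon. Within the data shown here, no measured step touches the group on the carbonyl carbon; compounds 1 and 2 differ there, but also at the saturated chain carbon, so their values alone cannot separate the two changes. Among the measured compounds shown here, with no direct precedent, a loss beyond the scatter is thought plausible but uncertain. The expected step is a number 19.5 percentage points lower from compound 1 to compound 4 (beyond the scatter), and compound 4 is estimated at 48% in this assay, within 22% to 74%.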

Compound 4, a percentage reported as inhibition, at one concentration (the size of the read-out at that concentration, not a potency): 20.6%
Compound 4: the middle estimate sits 27.4 percentage points above what was measured; the whole stated range lies above it.
By their numbers in this assay, from the lowest: compounds 3 and 4 (each within the scatter of the next); then compound 2; then compound 1.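

In this assay the group on the carbonyl carbon matters on its own: pyridin-4-yl in place of cyclopentyl gives a number 46.9 percentage points lower from compound 1 to compound 4 (beyond the scatter), with the rest of the structure unchanged. Within the data shown here, this is the first measured step at this position, and it is large. Nothing at hand explains the loss.

As far as these compounds go, it remains open whether the step follows the nitrogen of pyridin-4-yl or the change from a non-aromatic ring to an aromatic one. Phenyl on the same carbonyl carbon would separate these two readings.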